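Hydroxy to Methoxy on a Shared Cytotoxic Core

This account rests on a few compounds, and the source may have more. Where it says the series, first, only, none or still open, it means among the compounds named here.

Compound 1, `COc1cc2c(/C=C3/C(=O)Nc4ccc(O)cc43)c(Cl)n(Cc3cc(OC)c(OC)c(OC)c3)c2cc1C`: 50100 nM
Compound 2, `COc1ccc2c(c1)/C(=C\c1c(Cl)n(C/C=C/c3ccccc3)c3ccccc13)C(=O)N2`: 16200 nM

Both compounds were tested in a functional assay on cells (Cancer cell lines, Homo sapiens) for cytotoxicity, with a stated time of 48 h; a higher number here means a weaker inhibitor of growth, a lower number a stronger inhibitor of growth. Compound 1 gives 50100 nM, the highest number of the two, and so the weaker inhibitor of growth. Compound 2 gives 16200 nM; the gap between the two lies beyond the scatter of repeated measurements.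

Compound 3, `COc1ccc2c(c1)/C(=C\c1c(Cl)n(Cc3cc(OC)c(OC)c(OC)c3)c3cc(C)c(OC)cc13)C(=O)N2`, has not yet been measured. It differs from compound 1 in one place: methyl in place of hydrogen on an oxygen on an aromatic ring. Within the data shown here, no step between measured compounds shows what this change does. Compound 2 carries the methoxy group already, but it differs from compound 1 in other places as well, so its value alone cannot be credited to this change. A small step in either direction, or none beyond the scatter, is expected for the step of a 1.4-fold lower number from compound 1 to compound 3 (0.16 log units; within the scatter). Compound 3 is therefore estimated at 35000 nM, with a range from 12000 nM to 100000 nM.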

Compound 3, concentration for total growth inhibition: 95500 nM
Beside the measured number, compound 3's estimate is 2.7-fold (0.44 log units) below it, within the range that was stated.
By their numbers in this assay, from the lowest: compound 2; then compounds 1 and 3 (each within the scatter of the next).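

Swapping hydroxy for methoxy gives the first direct reading of this change on the shared core: in this assay, the step is a 1.9-fold higher number from compound 1 to compound 3 (0.28 log units; within the scatter), so the two compounds cannot be told apart here. At this position, then, methyl in place of hydrogen on an oxygen on an aromatic ring leaves growth inhibition without a difference that stands out from repeat measurements, and the free hydrogen is not shown to matter on this core. Nothing measured here bears on the reason for this result.

Still open, as far as these compounds go, is how a longer chain such as ethoxy, or a different group such as an amine or a carboxylic acid, would read in this place. A single pair also leaves open whether the same change would read alike on a core carrying other groups.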